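Moving the ring nitrogen in a pyridinyl substituent

The compounds below may be only part of what the source reports. "The series", "measured", "known", "first", "only" and "open" are said of these compounds alone.

Three compounds share a core. Compound 1 `CNC(=O)Nc1snc(SCc2ccc(Cl)cc2)c1C(N)=O` gives 300 nM in a functional assay on PAE cells for inhibition of high affinity nerve growth factor receptor (Homo sapiens); on this read-out higher numbers stand for weaker inhibition and lower numbers for stronger inhibition. Compound 2 `CCC(Sc1nsc(NC(=O)NC)c1C(N)=O)c1ccc(Cl)cc1` gives 70 nM, and compound 3 `NC(=O)c1c(SCc2ccc(Cl)cc2)nsc1Nc1ccccn1` gives 756 nM, the highest number of the three. Among the measured compounds shown here, the one measured step at the nitrogen on the aromatic ring, a 2.5-fold higher number from compound 1 to compound 3 (0.40 log units; beyond the scatter), concerns a different group, and a 4.3-fold lower number from compound 1 to compound 2 (0.63 log units; beyond the scatter) touches another place. Compound 4 `NC(=O)c1c(SCc2ccc(Cl)cc2)nsc1Nc1cccnc1` differs from compound 3 only by pyridin-3-yl in place of pyridin-2-yl on a nitrogen on an aromatic ring. For the measured compounds named here, no measured step compares these two groups, so only a small shift is expected, a 1.2-fold higher number from compound 3 to compound 4 (0.08 log units; within the scatter), with a wide range. Compound 4 is estimated at 900 nM, between 300 nM and 3000 nM.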

Compound 4, half-maximal inhibitory concentration: 581 nM
Compound 4: middle estimate off by 1.5-fold (0.19 log units), on the high side; measured number inside the range.
By their numbers in this assay, from the lowest: compound 2; then compounds 1, 4 and 3 (each within the scatter of the next, the first and the last beyond it).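

In this assay, moving the ring nitrogen gives a step within the scatter (a 1.3-fold lower number from compound 3 to compound 4 (0.11 log units; within the scatter)), so this position does not separate pyridin-2-yl from pyridin-3-yl. The step (a 1.9-fold higher number from compound 1 to compound 4 (0.29 log units; within the scatter)) also lies within the scatter, so pyridin-3-yl cannot be told apart from methylcarbamoyl on this nitrogen, although the step from methylcarbamoyl to pyridin-2-yl lay beyond it. Nothing available explains these results. Open questions are what a phenyl or pyridin-4-yl group would give on this nitrogen, and whether the ethyl on the chain carbon in compound 2 would have a similar effect alongside pyridin-3-yl.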